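Series notes: ring-methylated analogue of compound 3

A few compounds are considered here, and "the series" means these few. Any claim that something is new, unique, unknown or untested is made for them only; others in the source may bear on it.

Measured so far in this series:
compound 1, `CC1=CC[C@@H]([C@@](C)(O)CCCC(C)(C)NC=S)CC1`, gives > 100000 nM in a functional assay on NCI/ADR cells (Homo sapiens) for cytotoxicity, read by sulforhodamine B assay (on this read-out higher numbers stand for weaker inhibition of growth and lower numbers for stronger inhibition of growth), which is a limit of the assay and not a number.
compound 2, `CC1=CC[C@@H]([C@@](C)(O)CCCC(C)(C)NC(=S)NN)CC1`, gives 29000 nM in this assay.
compound 3, `CC1=CC[C@@H]([C@@](C)(O)CCCC(C)(C)NC(=S)N/N=C\c2ccccc2)CC1`, gives 23800 nM in this assay.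

Compound 3 holds the lowest of the two numbers, with compound 2 within the scatter of it; the remaining value is a limit. The steps of an at least 3.4-fold lower number from compound 1 to compound 2 (0.53 log units; beyond the scatter) and an at least 4.2-fold lower number from compound 1 to compound 3 (0.62 log units; beyond the scatter) lie beyond the scatter, whereas a 1.2-fold lower number from compound 2 to compound 3 (0.09 log units; within the scatter) stays within it.

Compound 4, `CC1=CC[C@@H]([C@@](C)(O)CCCC(C)(C)NC(=S)N/N=C\c2ccc(C)cc2)CC1`, differs from compound 3 by methyl in place of hydrogen on an aromatic carbon. Among the measured compounds shown here, no measured step touches this aromatic ring; the only step at the outer end of the chain, from compound 2 to compound 3, stayed within the scatter, and a change as small as this is expected to do likewise, as a step of a 1.2-fold lower number from compound 3 to compound 4 (0.08 log units; within the scatter). Compound 4 is therefore estimated at 20000 nM, expected between 8000 nM and 50000 nM.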

Compound 4, concentration for total growth inhibition: 30500 nM
Beside the measured number, compound 4's estimate is 1.5-fold (0.18 log units) below it; the measured number falls inside the stated range.
By their numbers in this assay, from the lowest: compounds 3, 2 and 4 (each within the scatter of the next). At a limit, above all of these: compound 1.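

In this assay the step from phenyl to 4-methylphenyl, para to a large group, reads a 1.3-fold higher number from compound 3 to compound 4 (0.11 log units; within the scatter) and stays within the scatter, so this position on the aromatic ring takes a methyl without a change beyond it. The reading a 1.1-fold higher number from compound 2 to compound 4 (0.02 log units; within the scatter) also stays within the scatter, so the 4-methylphenyl end adds nothing beyond the scatter over the shorter end of compound 2. Nothing at hand bears on a cause for this result.

From the compounds shown here alone, whether a chlorine, a methoxy group or a carboxylic acid at this position would move the number beyond the scatter stays open. So does the effect of a methyl elsewhere on the ring.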